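Shortening the Sulfonamide Tail to a Methyl Group

A few compounds are considered here, and "the series" means these few. Any claim that something is new, unique, unknown or untested is made for them only; others in the source may bear on it.

Measured in a functional assay (plasma) for inhibition, with Oryctolagus cuniculus as the target; on this read-out higher numbers stand for weaker inhibition and lower numbers for stronger inhibition:
Compound 1, `Cc1ccc(S(=O)(=O)N[C@H]2C3CC[C@H](C3)[C@@H]2C/C=C\CCCC(=O)O)cc1`: 500 nM
Compound 2, `O=C(O)CCC/C=C\C[C@H]1[C@@H]2CCC(C2)[C@@H]1NS(=O)(=O)c1ccccc1`: 1000 nM; 7400 nM; 600 nM (3 entries)
Compound 3, `O=C(O)CCC/C=C\C[C@H]1[C@@H]2CCC(C2)[C@@H]1NS(=O)(=O)CCCc1ccccc1`: 14000 nM

Compound 3 stands highest of the two single numbers in this assay; compound 2 has only several scattered entries, (the several entries of compound 2 in this assay, 1000 nM; 7400 nM; 600 nM (3 entries)). Among the measured compounds shown here, the one measured step that bears on the sulfonyl substituent is a 28-fold higher number from compound 1 to compound 3 (1.45 log units; beyond the scatter), a large weakening when the aromatic group was moved out on a chain. Compound 4, `CS(=O)(=O)N[C@H]1C2CC[C@H](C2)[C@@H]1C/C=C\CCCC(=O)O`, goes further: hydrogen in place of phenethyl on a saturated chain carbon bound to a sulfonyl sulfur. For the measured compounds named here, no measured step covers losing the aromatic ring entirely, so the direction is uncertain; a modest further weakening is expected, a 1.8-fold higher number from compound 3 to compound 4 (0.25 log units; within the scatter). Compound 4 is therefore estimated at 25000 nM, within 6000 nM to 100000 nM.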

Compound 4, half-maximal inhibitory concentration: 640000 nM
Compound 4: the middle estimate sits 26-fold (1.41 log units) below what was measured, and the stated range ends below it.
By their numbers in this assay, from the lowest: compound 1; then compound 3; then compound 4.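

In this assay, the step of a 1300-fold higher number from compound 1 to compound 4 (3.11 log units; beyond the scatter) is the largest loss seen on the sulfonyl sulfur, so methyl is far from an equal replacement for 4-methylphenyl. Even an aromatic ring held out on the 3-phenylpropyl chain counts for a great deal, as the step of a 46-fold higher number from compound 3 to compound 4 (1.66 log units; beyond the scatter) shows. Nothing measured here explains why.

Compound 4 loses the ring and the chain together, so their shares cannot be separated. A plain butyl chain on the sulfonyl sulfur, with no ring, would be needed to tell them apart.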